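A few compounds are considered here, and "the series" means these few. Any claim that something is new, unique, unknown or untested is made for them only; others in the source may bear on it.

Compound 2, `COc1cc(OC)c2c(=O)cc(-c3ccc(OC4CCNCC4)cc3)oc2c1`, is one of three measured members of a set built on a shared core, in which compound 1, `COc1cc(OC)c2c(=O)cc(-c3ccc(OCCCN(C)C)cc3)oc2c1`, and compound 3, `COc1cc(OC)c2c(=O)cc(-c3ccc(OCC(O)CN(C)C)cc3)oc2c1`, carry different side chains on the same aromatic carbon. Going by the values given here, in a functional assay (Homo sapiens) for antiproliferative activity, read by resazurin assay, with a stated time of 48 h, tested at 5 uM (on this read-out higher numbers stand for a stronger effect at the one concentration tested and lower numbers for a weaker effect), compound 1 gives 36%; in the same assay compound 3 gives 42%, and the step of a number 6 percentage points higher from compound 1 to compound 3 (within the scatter) is the only one-point change among the measured compounds. Among the compounds with values here, for compound 2 the assay gives "not active" (no number reported), so no number places it among the others; it stands apart as the one compound without a reading.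

Compound 4, `COc1cc(OC)c2c(=O)cc(-c3ccc(Br)cc3)oc2c1`, differs from compound 2 by bromo in place of (piperidin-4-yl)oxy on an aromatic carbon. Within the data shown here, no measured step resembles this change: the step from compound 1 to compound 3 alters a chain rather than removing one, and its size says nothing about exchanging (piperidin-4-yl)oxy for bromo. Starting from a compound with no reading, the expectation can only be modest. Compound 4 is estimated at 20%, in a range from 0% to 45%.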

Compound 4, a percentage reported as inhibition, at one concentration (the size of the read-out at that concentration, not a potency): 12%
Estimate against measurement, compound 4: 8 percentage points above, within the range that was stated.
By their numbers in this assay, from the lowest: compound 4; then compounds 1 and 3 (each within the scatter of the next).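

Replacing either side chain with bromo lowers the read-out in this assay by an amount beyond the scatter, giving a number 30 percentage points lower from compound 3 to compound 4 (beyond the scatter) and a number 24 percentage points lower from compound 1 to compound 4 (beyond the scatter) as well. This aromatic carbon had so far shown only a change within a chain, and now it responds when the whole chain is exchanged for a single atom. Compound 2 goes against any reading that a side chain here is enough, since its (piperidin-4-yl)oxy group gives "not active" without a number, and so its step to compound 4 cannot be read.

The compounds shown leave open how a smaller group such as methoxy, or a longer chain ending in dimethylamino, would read at this place. No evidence at hand explains the drop.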